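The compounds below may be only part of what the source reports. "The series", "measured", "known", "first", "only" and "open" are said of these compounds alone.

Measured compounds in the series:
- compound 1, `CC1(C)C[C@@H](CN([C@H](CCC(F)(F)F)C(N)=O)S(=O)(=O)c2ccc(Cl)cc2)O1`: 16.5 mL/min/kg
- compound 2, `NC(=O)[C@@H](CCC(F)(F)F)N(C[C@H]1CCCOC1)S(=O)(=O)c1ccc(Cl)cc1`: 156 mL/min/kg
- compound 3, `NC(=O)[C@@H](CCC(F)(F)F)N(C[C@H]1CCOC1)S(=O)(=O)c1ccc(Cl)cc1`: 83.4 mL/min/kg

All three numbers come from an in vitro ADME assay on microsomes from liver (Homo sapiens) for metabolic stability, read by HPLC; a higher number here means faster removal of the compound, a lower number slower removal. Among them compound 3 sits second highest of the three. Its nearest neighbour is compound 2, since a 1.9-fold lower number from compound 2 to compound 3 (0.27 log units; within the scatter); its furthest is compound 1, since a 5.1-fold higher number from compound 1 to compound 3 (0.70 log units; beyond the scatter). The remaining measured step is a 9.5-fold higher number from compound 1 to compound 2 (0.98 log units; beyond the scatter).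

Compound 4, `NC(=O)[C@@H](CCC(F)(F)F)N(C[C@@H]1CCOC1)S(=O)(=O)c1ccc(Cl)cc1`, is the next entry. Relative to compound 3 the change is the two compounds have the same atoms and bonds and differ only in configuration as drawn: 1 of 2 stereo elements differ; a stereocentre at a saturated ring carbon is drawn R in compound 3 and S in compound 4.

Among the measured compounds shown here, none of the three measured steps bears directly on this change: each of them swaps one saturated oxygen-containing ring for another at the carbon bound to the sulfonamide nitrogen, while the ring-carbon configuration is kept, and the data hold no pair that differs in configuration alone. The two ring swaps that move away from compound 1 are modest and beyond the scatter, whereas the swap between compound 2 and compound 3 stays within it. Without any precedent for an inversion of the ring stereocentre, no step beyond the scatter is expected in this assay from compound 3 to compound 4; the expected step is a 1.0-fold lower number from compound 3 to compound 4 (0.02 log units; within the scatter). Compound 4 is therefore estimated at 80 mL/min/kg, with a range from 40 mL/min/kg to 160 mL/min/kg.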

Compound 4, clearance: 69.8 mL/min/kg
The estimate for compound 4 lay 1.1-fold (0.06 log units) above the measured number; the measured number falls inside the stated range.
By their numbers in this assay, from the lowest: compound 1; then compounds 4, 3 and 2 (each within the scatter of the next, the first and the last beyond it).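

In this assay, among the compounds shown here, this is the first pair to test configuration at the ring carbon, and inverting that stereocentre produces no step beyond the scatter: a 1.2-fold lower number from compound 3 to compound 4 (0.08 log units; within the scatter). The step from the oxan-3-yl ring does reach beyond the scatter with the S-drawn oxolan-3-yl, a 2.2-fold lower number from compound 2 to compound 4 (0.35 log units; beyond the scatter), but not with the R-drawn one, a 1.9-fold lower number from compound 2 to compound 3 (0.27 log units; within the scatter); since the two oxolan-3-yl compounds lie within the scatter of each other, this contrast carries little weight. Compound 1 remains apart from the S-drawn oxolan-3-yl as well, a 4.2-fold higher number from compound 1 to compound 4 (0.63 log units; beyond the scatter), so at this position the 4,4-dimethyloxetan-2-yl swap stands out in the series, while the small step within the oxolan-3-yl pair can be read on configuration alone: the fact that compounds 3 and 4 differ only in the configuration as drawn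

On these data alone, whether inversion is equally quiet on the oxan-3-yl or 4,4-dimethyloxetan-2-yl rings, or at the second stereocentre, remains open. An unsubstituted oxetan-2-yl ring or a cyclopentyl ring at the same place would be needed to separate the contributions of the two methyl groups, the ring size and the ring oxygen to the gap between compound 1 and the others.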